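A few compounds are considered here, and "the series" means these few. Any claim that something is new, unique, unknown or untested is made for them only; others in the source may bear on it.

Three compounds that share one core have been run through a functional assay on ACHN cells (Homo sapiens) for inhibition, read by sulforhodamine B assay, with a stated time of 48 h, tested at 10 uM; on this read-out higher numbers stand for more inhibition at the one concentration tested (going by the name of the read-out) and lower numbers for less inhibition. Compound 1 `c1ccc2c(-c3cn4ccnc4c(-c4ccc5ncn(C6CCCCC6)c5c4)n3)cccc2c1` gives 6.49% in this assay, compound 2 `Fc1ccc(-c2cn3ccnc3c(-c3ccc4ncn(C5CCCCC5)c4c3)n2)cc1` gives 9.02%, and compound 3 `CC(=O)c1ccc(-c2cn3ccnc3c(-c3ccc4ncn(C5CCCCC5)c4c3)n2)cc1` gives 4.32%, the lowest of the three numbers, though the steps of a number 2.2 percentage points lower from compound 1 to compound 3 (within the scatter) and a number 4.7 percentage points lower from compound 2 to compound 3 (within the scatter) are both within the scatter. The step of a number 2.5 percentage points higher from compound 1 to compound 2 (within the scatter) is likewise within the scatter, so the three aryl groups tried so far have not separated from one another in this assay.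

Compound 4 `Fc1ccccc1-c1cn2ccnc2c(-c2ccc3ncn(C4CCCCC4)c3c2)n1` is the next compound to be measured. The change from compound 3 is 2-fluorophenyl in place of 4-acetylphenyl on an aromatic carbon. Two of the measured steps bear on it: a number 4.7 percentage points lower from compound 2 to compound 3 (within the scatter), which already tested fluoro against acetyl on the phenyl ring, and a number 2.5 percentage points higher from compound 1 to compound 2 (within the scatter), which brought in a fluorophenyl group. Neither moved beyond the scatter, and nothing in the data suggests that shifting the fluorine to another position of the phenyl ring should do more. The step from compound 3 to compound 4 is therefore expected to be a number 2.7 percentage points higher from compound 3 to compound 4 (within the scatter), not beyond the scatter. Compound 4 is estimated to give 7% in this assay, within a range from 0% to 16%.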

Compound 4, a percentage reported as inhibition, at one concentration (the size of the read-out at that concentration, not a potency): 13.2%
For compound 4 the middle estimate is 6.2 percentage points below the measured one, within the range that was stated.
By their numbers in this assay, from the lowest: compounds 3, 1, 2 and 4 (each within the scatter of the next).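

With the 2-fluorophenyl group, this position on the shared core has now carried four different aryl groups in this assay, and the step of a number 8.9 percentage points higher from compound 3 to compound 4 (within the scatter) is the largest seen here, yet it still does not separate the 2-fluorophenyl group from 4-acetylphenyl. Going by these compounds alone, the step of a number 4.2 percentage points higher from compound 2 to compound 4 (within the scatter) is the first comparison in which only the place of the fluorine on the phenyl ring changes, and it shows that this move does not separate the two fluorophenyl compounds either, just as the step of a number 6.7 percentage points higher from compound 1 to compound 4 (within the scatter) leaves 2-fluorophenyl and naphthalen-1-yl unseparated. No independent measurement is available to account for any of these numbers.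

What the four compounds leave open is whether any group at this position can move the inhibition beyond the scatter, since every group tried so far is an aryl group and none is, for example, an amine, a carboxylic acid or a longer alkyl chain. They also leave open how far these single-concentration percentages reflect potency, as all four compounds were read at only one concentration.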